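The source may report more compounds than this note shows. Statements on the series, on what has been measured and on what is new or still open speak of the compounds shown alone.

Compound 2 `Cc1c(N2CC3CC3(N)C2)c(F)cc2c(CN)cc(=O)n(C3CC3)c12` is the starting point. In an ADME assay on NIH3T3 cells (Mus musculus, strain BALB/c) for cytotoxicity, read by neutral red uptake, with stated times of 1 h, 50 min and 24 h (a lower number here means a stronger inhibitor, a higher number a weaker inhibitor), compound 2 gives 3030 nM. Among the measured compounds shown here, the only other measured compound, compound 1 `Cc1c(N2CC3CC3(N)C2)c(F)cc2c(CN)c(F)c(=O)n(C3CC3)c12`, gives 1610 nM in this assay, and the two numbers lie within the scatter of each other: the step of a 1.9-fold higher number from compound 1 to compound 2 (0.27 log units; within the scatter) is too small to count as a real change. Compound 3 `Cc1c(N2CC[C@H](N)C2)c(F)cc2c(CN)cc(=O)n(C3CC3)c12` has not yet been measured. It differs from compound 2 at one place: a group of 6 heavy atoms (4 carbon, 2 nitrogen; one five-membered non-aromatic ring with 1 hetero atom) in place of a group of 7 heavy atoms (5 carbon, 2 nitrogen; one three-membered non-aromatic ring of carbon only, one five-membered non-aromatic ring with 1 hetero atom), on an aromatic carbon. For the measured compounds named here, the one measured step concerns a fluoro group being replaced by hydrogen, a different part of the shared core, so it says nothing direct about swapping one amine ring for another. Going by the values given here, with no step that bears on this change, the expectation is a number close to that of compound 2, with no movement beyond the scatter in either direction, so the estimated step of a 1.0-fold lower number from compound 2 to compound 3 (0.00 log units; within the scatter) is expected to be small. Compound 3 is therefore estimated to give about 3000 nM in this assay, likely between 1200 nM and 7500 nM.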

Compound 3, half-maximal inhibitory concentration: 288000 nM
For compound 3 the middle estimate is 96-fold (1.98 log units) below the measured one; measured number above the stated range.
By their numbers in this assay, from the lowest: compounds 1 and 2 (each within the scatter of the next); then compound 3.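

In this assay, putting 3-aminopyrrolidin-1-yl in place of the larger amine group that carries the three-membered ring of carbon only gives a 95-fold higher number from compound 2 to compound 3 (1.98 log units; beyond the scatter). This shows that the group on this aromatic carbon, ortho to a fluoro group and ortho to a methyl group, can shift the number far beyond the scatter, which the earlier step, made elsewhere on the shared core, could not reveal. The change looks modest on paper, since the hydrogen-bond donor and acceptor counts stay the same and neither group has a net charge, so these counts do not separate the two compounds, and no measurement here explains the size of the rise.

The compounds shown leave open whether the three-membered ring itself matters or whether the defined stereocentre of 3-aminopyrrolidin-1-yl also plays a part, as its mirror-image form does not appear among them. They also leave open how a different group at this carbon, such as a simple open-chain dimethylamino group, would behave, and whether a fluoro group on the shared core would matter alongside 3-aminopyrrolidin-1-yl.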